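Working notes: from compound 3 to compound 4

The source may hold more compounds than are shown below. What is called first, only, known or untested is meant among the compounds shown, and "the series" means these compounds.

Measured in an ADME assay on L929 cells (Mus musculus) for cytotoxicity, read by resazurin assay, with a stated time of 72 h; on this read-out higher numbers stand for weaker inhibition and lower numbers for stronger inhibition:
- compound 1 `COCOc1cccc(C(=O)/C=C/c2ccc3c(c2)B(O)OC3)c1`: > 10 ug/mL (a limit)
- compound 2 `O=C(/C=C/c1ccc2c(c1)B(O)OC2)c1cccs1`: > 10 ug/mL (a limit)
- compound 3 `O=C(/C=C/c1ccc2c(c1)B(O)OC2)c1ccc(Cl)cc1`: > 10 ug/mL (a limit)

None of these three results is a number, so the compounds cannot be ranked. Going by the values given here, compound 3 stands only at a limit, as do the other two, and the series so far shows (the limit of > 10 ug/mL in this assay, at which 3 of the 3 values shown sit).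

The next compound is compound 4 `O=C(/C=C/c1ccc2c(c1)B(O)OC2)c1cccc(F)c1`. The structural change is 3-fluorophenyl in place of 4-chlorophenyl on a carbonyl carbon. The group leaving and the group entering are both substituted phenyl rings, and the rest of the structure stays the same.

Among the compounds with values here, the one measured step at this carbonyl carbon is a step that the two limits leave unreadable from compound 2 to compound 3. It gives no size that could be carried over to the new change, and it gives no direction.

In this assay, no step beyond the scatter is therefore expected, and no direction is predicted. Compound 4 is expected to be reported as a limit as well, because compound 3 carries > 10 ug/mL. A numeric result remains possible, and the estimate allows for one.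

The estimate means a step that the limit leaves unreadable from compound 3 to compound 4, an expected step and not a measured one. For compound 4 the estimated value is 12 ug/mL, with an expected range from 5 ug/mL to 30 ug/mL.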

Compound 4, half-maximal inhibitory concentration: > 10 ug/mL
Compound 4: only a limit was reported; the forecaster's own chance of this, stated with the estimate: 75%; the middle value is on the limit's open side.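

In this assay compound 4 gives > 10 ug/mL, which is a limit and not a number. The steps to compound 4 from compound 1, compound 2 and compound 3 therefore cannot be read: the limit of > 10 ug/mL in this assay, at which 4 of the 4 values shown sit.

The compounds shown leave open how these four compare, and whether any change on the carbonyl carbon shifts the read-out.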